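Swapping the Terminal Phenyl for a Dimethylbenzoxazole

A few compounds are considered here, and "the series" means these few. Any claim that something is new, unique, unknown or untested is made for them only; others in the source may bear on it.

Measured compounds:
Compound 1, `O=C(O)CCCSCCN1C(=O)CC[C@@H]1/C=C/[C@@H](O)Cc1cccc(N2Cc3ccccc3C2)c1`, gives 4.4 nM.
Compound 2, `O=C(O)c1csc(SCCN2C(=O)CC[C@@H]2/C=C/[C@@H](O)Cc2cccc(-c3ccccc3)c2)n1`, gives 0.94 nM.

Both were tested in an assay on CHO cells for displacement of a labelled ligand from prostaglandin E2 receptor EP4 subtype (Mus musculus), read by scintillation counting, with a stated time of 60 min; on this read-out lower numbers stand for stronger inhibition and higher numbers for weaker inhibition. Of the two numbers, compound 2 has the lower one, and the gap between compound 2 and compound 1 lies beyond the usual scatter, so compound 2 is the stronger binder of the pair.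

Compound 3, `Cc1cc(C)c2oc(-c3cccc(C[C@H](O)/C=C/[C@H]4CCC(=O)N4CCSc4nc(C(=O)O)cs4)c3)nc2c1`, has not yet been measured. It differs from compound 2 in one place: 5,7-dimethyl-1,3-benzoxazol-2-yl in place of phenyl on an aromatic carbon. The shared core, including the acid-bearing heterocycle on the chain and the hydroxyl-bearing side arm, is kept unchanged.

Among the compounds with values here, no measured pair shows this particular swap, so the expectation rests on compound 2 alone. The expected step of a 1.2-fold lower number from compound 2 to compound 3 (0.07 log units; within the scatter) is small, within the scatter, with no clear direction. Compound 3 is expected to give about 0.8 nM, in a range from 0.2 nM to 3 nM.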

Compound 3, inhibition constant: 0.15 nM
For compound 3 the middle estimate is 5.3-fold (0.73 log units) above the measured one, and the stated range ends above it.
By their numbers in this assay, from the lowest: compound 3; then compound 2; then compound 1.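

In this assay, the aromatic carbon that carries phenyl, meta to a large group, turns out to accept a larger group with two aromatic rings, and binding improves: 5,7-dimethyl-1,3-benzoxazol-2-yl in place of phenyl gives a 6.3-fold lower number from compound 2 to compound 3 (0.80 log units; beyond the scatter). This shows that phenyl is not the best group at this position, and that a ring holding nitrogen and oxygen is well accepted there. No measurement here explains why the number falls.

The swap changes the ring system and adds the two methyl groups in a single step, so the compounds shown cannot tell which of these changes matters. The plain 1,3-benzoxazol-2-yl group without methyl groups, or a 1,3-benzothiazol-2-yl group at the same place, would help to separate these effects.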